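Imidazolyl thioether series: positional isomer of compound 3

The source may hold more compounds than are shown below. What is called first, only, known or untested is meant among the compounds shown, and "the series" means these compounds.

Among the measured compounds shown here, compound 3 `N#Cc1c(N)nc(SCc2ncc[nH]2)c(C#N)c1-c1ccc(OCC2CC2)cc1` gives 9.5 nM in a functional assay on CHO cells for agonist activity at adenosine receptor A2b (Homo sapiens), read by AlphaScreen and cAMP accumulation (a lower number here means that less compound is needed, a higher number that more compound is needed for the effect), the lowest of the three numbers measured so far. Compound 1 `N#Cc1c(N)nc(SCC(N)=O)c(C#N)c1-c1ccc(OCC2CC2)cc1` gives 31 nM and compound 2 `N#Cc1c(N)nc(SCC(=O)NCO)c(C#N)c1-c1ccc(OCC2CC2)cc1` gives 182 nM; the steps of a 3.3-fold lower number from compound 1 to compound 3 (0.51 log units; beyond the scatter) and a 19-fold lower number from compound 2 to compound 3 (1.28 log units; beyond the scatter) both end at the 1H-imidazol-2-yl group on the saturated chain carbon bound to a sulfur. Compound 4 `N#Cc1c(N)nc(SCc2cnc[nH]2)c(C#N)c1-c1ccc(OCC2CC2)cc1` differs from compound 3 by 1H-imidazol-5-yl in place of 1H-imidazol-2-yl on a saturated chain carbon bound to a sulfur. For the measured compounds named here, no measured pair bears directly on this change: the two steps into compound 3 exchange the whole group, not the point at which the ring is attached. The expectation for compound 4 is therefore a step within the scatter, with some room for a modest rise, a 1.7-fold higher number from compound 3 to compound 4 (0.23 log units; within the scatter). Compound 4 is estimated at 16 nM, with a range from 5 nM to 50 nM.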

Compound 4, half-maximal effective concentration: 139 nM
The estimate for compound 4 lay 8.7-fold (0.94 log units) below the measured number; measured number outside the range, above it.
By their numbers in this assay, from the lowest: compound 3; then compound 1; then compounds 4 and 2 (each within the scatter of the next).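

The point of attachment on the imidazole ring matters at this position: the same atoms joined differently give a large step (a 15-fold higher number from compound 3 to compound 4 (1.17 log units; beyond the scatter)), so the advantage over carbamoyl belongs to 1H-imidazol-2-yl, not to imidazole as such. 1H-imidazol-5-yl is worse than carbamoyl (a 4.5-fold higher number from compound 1 to compound 4 (0.65 log units; beyond the scatter)) and not separated from (hydroxymethyl)carbamoyl (a 1.3-fold lower number from compound 2 to compound 4 (0.12 log units; within the scatter)). Nothing available explains the difference between the two attachment points.

Open, as far as these compounds go, is whether 1H-1,2,4-triazol-3-yl or pyridin-2-yl on the saturated chain carbon bound to a sulfur would match 1H-imidazol-2-yl. Also open, from the compounds shown here alone, is how a longer chain carrying 1H-imidazol-2-yl would behave.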